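A 2-Chlorobenzyl to 4-Chlorobenzyl Swap Under Test

The compounds below may be only part of what the source reports. "The series", "measured", "known", "first", "only" and "open" are said of these compounds alone.

Of the compounds shown here, three have been measured in a functional assay on DU-145 cells (Homo sapiens) for inhibition, read by trypan blue exclusion, with a stated time of 96 h; on this read-out lower numbers stand for stronger inhibition of growth and higher numbers for weaker inhibition of growth. Compound 1 `O=C(/C(=C\c1ccc(OCc2ccccc2)cc1)SCc1ccc(Cl)cc1)c1ccc(Cl)cc1` gives 1000 nM, and compound 2 `O=C(/C(=C\c1ccc(O)cc1O)SCc1ccc(Cl)cc1)c1ccc(Cl)cc1` gives 50000 nM. Compound 3 `CN(C)c1ccc(/C=C(/SCc2ccccc2Cl)C(=O)c2ccc(Cl)cc2)cc1` gives > 100000 nM, which is a limit of the assay and not a number. Compound 3 therefore stands at the limit of > 100000 nM in this assay, at which 1 of the 3 values shown sits.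

Compound 4 `CN(C)c1ccc(/C=C(/SCc2ccc(Cl)cc2)C(=O)c2ccc(Cl)cc2)cc1` has the same atoms as compound 3, joined differently: 4-chlorophenyl in place of 2-chlorophenyl on a saturated chain carbon bound to a sulfur. It carries 4-chlorophenyl in place of 2-chlorophenyl on a saturated chain carbon bound to a sulfur. For the measured compounds named here, no measured pair isolates this change in this assay, so any expectation is rough. The 4-chlorobenzyl group also appears in compound 1 at 1000 nM and in compound 2 at 50000 nM, and both gave numbers, although they differ from compound 4 elsewhere. A step toward stronger inhibition of growth is therefore expected, with its estimated size being an at least 10-fold lower number from compound 3 to compound 4 (1.00 log units; beyond the scatter). For compound 4 the estimated value is 10000 nM, with an expected range from 700 nM to 100000 nM.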

Compound 4, concentration for 50% growth inhibition: > 100000 nM
Compound 4 gave a limit, no number; the forecaster's own chance of this, stated with the estimate: 20%; at least 10-fold (1.00 log units) between middle value and limit.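

In this assay compound 4 gives > 100000 nM, which is a limit of the assay and not a number. The step for 4-chlorophenyl in place of 2-chlorophenyl on a saturated chain carbon bound to a sulfur therefore cannot be read, as both compounds rest on the same limit: the limit of > 100000 nM in this assay, at which 2 of the 4 values shown sit.

What is new is that the 4-chlorobenzyl group does not by itself secure a measurable value: dimethylamino in place of benzyloxy on an aromatic carbon gives an at least 100-fold higher number from compound 1 to compound 4 (2.00 log units; beyond the scatter), while 4-(dimethylamino)phenyl in place of 2,4-dihydroxyphenyl gives an at least 2.0-fold higher number from compound 2 to compound 4 (0.30 log units; that floor lies within the scatter).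

From the compounds shown here alone, how 2-chlorobenzyl and 4-chlorobenzyl compare on a core that gives a number, such as that of compound 1, remains open. Also open, going by these compounds, is what a methoxy group or a primary amine would give in place of dimethylamino on that aromatic carbon.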